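This account rests on a few compounds, and the source may have more. Where it says the series, first, only, none or still open, it means among the compounds named here.

Compound 1 `N[C@H]1CC[C@H](Nc2c(C(=O)NCc3ccco3)nc(Br)c3cccnc23)CC1`: > 10000 nM
Compound 2 `NCCCNc1c(C(=O)NCc2ccc(F)cc2)ncc2cccnc12`: > 10000 nM

Both measured compounds were tested in a functional assay on HCT-116 cells (Homo sapiens) for cytotoxicity, read by MTT assay, with a stated time of 72 h; a higher number here means a weaker inhibitor, a lower number a stronger inhibitor. Compound 1 gives > 10000 nM in this assay, which is a limit of the assay rather than a number. Compound 2 likewise gives > 10000 nM in this assay, again only a limit. Compound 1 thus stands at the limit of > 10000 nM in this assay, at which 2 of the 2 values shown sit, and nothing finer can be said of where it lies. Compound 3 `N[C@H]1CC[C@H](Nc2c(C(=O)NC3CCCCC3)nc(Br)c3cccnc23)CC1` has not yet been measured. It keeps the core of compound 1 and differs in one place: cyclohexyl in place of (furan-2-yl)methyl on an amide-type nitrogen. Within the data shown here, no step between two measured compounds is known here, and the size of this change has nothing measured to lean on. With both measured compounds sitting at the limit, compound 3 is expected to stay near it, and the step that the limit leaves unreadable from compound 1 to compound 3 is expected to be none beyond the usual scatter. Compound 3 is therefore estimated at 15000 nM, within a range from 3000 nM to 60000 nM.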

Compound 3, half-maximal inhibitory concentration: > 10000 nM
Compound 3 was reported as a limit; the forecaster's own chance of this, stated with the estimate: 75%; the middle value is on the limit's open side.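

Compound 1 and compound 3 both give a limit rather than a number, so no step between them can be read: the limit of > 10000 nM in this assay, at which 3 of the 3 values shown sit.

The compounds shown leave open how strong each one really is in this assay, and which change, if any, would give a value that can be read as a number.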